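The source may hold more compounds than are shown below. What is called first, only, known or untested is meant among the compounds shown, and "the series" means these compounds.

In a physicochemical assay for lipophilicity, at pH 7.4 (a higher number here means a more lipophilic compound, a lower number a more polar compound), compound 2 `CNC(=O)c1cccc(NC(=O)[C@H]2CCCN2C(=O)C2(c3cccc(Cl)c3)CCCC2)c1` stands highest of the two measured at 5.5 and compound 1 `O=C(Nc1cnc2[nH]ncc2c1)[C@H]1CCCN1C(=O)C1(c2cccc(Cl)c2)CCCC1` reads 4.9 on the same scale. Compound 3 `O=C(Nc1ccc2[nH]nnc2c1)[C@H]1CCCN1C(=O)C1(c2cccc(Cl)c2)CCCC1` is reached from compound 2 through a group of 9 heavy atoms (6 carbon, 3 nitrogen; one five-membered aromatic ring with 3 hetero atoms, one six-membered aromatic ring of carbon only) in place of a group of 10 heavy atoms (8 carbon, 1 nitrogen, 1 oxygen; one six-membered aromatic ring of carbon only), on an amide-type nitrogen and remains unmeasured. Going by the values given here, the only measured step bearing on this is a number 0.60 log units higher from compound 1 to compound 2 (beyond the scatter) where the 3-(methylcarbamoyl)phenyl group entered and a group of 9 heavy atoms left, the reverse of the present exchange, though the entering group here has a different ring content. A modest fall beyond the scatter is expected, with a number 0.50 log units lower from compound 2 to compound 3 (beyond the scatter) as the estimated step in this assay for now. Compound 3 is estimated at 5 with 4.6 to 5.4 as its expected range.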

Compound 3, distribution coefficient: 5.2
Estimate against measurement, compound 3: 0.20 log units below; measured number inside the range.
By their numbers in this assay, from the lowest: compounds 1, 3 and 2 (each within the scatter of the next, the first and the last beyond it).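

In this assay the exchange of 3-(methylcarbamoyl)phenyl on the amide-type nitrogen gives a number 0.30 log units lower from compound 2 to compound 3 (within the scatter) and so does not by itself bring a step beyond the scatter. The two groups of 9 heavy atoms, which differ in ring content, give a number 0.30 log units higher from compound 1 to compound 3 (within the scatter) and are not told apart at this position, so the ring change between them has no readable effect here. Nothing on hand accounts for these steps.

From the compounds shown here alone, whether a basic amine or a carboxylic acid on the group at this nitrogen would give a step beyond the scatter remains open.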